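The compounds below may be only part of what the source reports. "The series", "measured", "known", "first", "only" and "open" are said of these compounds alone.

Three compounds that share one core and differ only in a single group on an aromatic carbon have been measured in a functional assay on NCI-H23 cells (Homo sapiens) for cytotoxicity, read by colorimetric assay; a lower number here means a stronger inhibitor, a higher number a weaker inhibitor. Compound 1 (`Cc1ccc2c(c1)/C(=C1/Nc3ccccc3/C1=N\O)C(=O)N2Cc1ccc(/C=C/C(=O)NO)cc1`), with methyl, gives 10 nM. Compound 2 (`COc1ccc2c(c1)/C(=C1/Nc3ccccc3/C1=N\O)C(=O)N2Cc1ccc(/C=C/C(=O)NO)cc1`), with methoxy, gives 50 nM. Compound 3 (`O=C(/C=C/c1ccc(CN2C(=O)/C(=C3\Nc4ccccc4\C3=N/O)c3cc(F)ccc32)cc1)NO`), with fluoro, gives 8 nM. That places it level with compound 1 at the low end of the three numbers, and the exchange of methyl for fluoro amounts to a 1.3-fold lower number from compound 1 to compound 3 (0.10 log units; within the scatter). Both stand apart from the methoxy compound, as shown by a 5.0-fold higher number from compound 1 to compound 2 (0.70 log units; beyond the scatter) and by a 6.3-fold lower number from compound 2 to compound 3 (0.80 log units; beyond the scatter).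

Compound 4 (`O=C(/C=C/c1ccc(CN2C(=O)/C(=C3\Nc4ccccc4\C3=N/O)c3ccccc32)cc1)NO`) carries no group at that carbon: hydrogen in place of fluoro on an aromatic carbon. Among the measured compounds shown here, no measured compound has hydrogen there, so the data offer no direct comparison. The closest guide is the small exchange from methyl to fluoro, a 1.3-fold lower number from compound 1 to compound 3 (0.10 log units; within the scatter), since the two larger steps both involve methoxy, which plays no part in this change. A small shift is therefore expected, with no clear direction from the data. The estimated step is a 1.4-fold higher number from compound 3 to compound 4 (0.14 log units; within the scatter), which would not be a clear separation. In this assay compound 4 is expected at 11 nM, with an estimated range from 4 nM to 30 nM.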

Compound 4, half-maximal inhibitory concentration: 9 nM
Beside the measured number, compound 4's estimate is 1.2-fold (0.09 log units) above it; measured number inside the range.
By their numbers in this assay, from the lowest: compounds 3, 4 and 1 (each within the scatter of the next); then compound 2.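

With hydrogen at this carbon, the series in this assay gains the reference it lacked, a compound with no group at that position. Against that reference neither fluoro (a 1.1-fold higher number from compound 3 to compound 4 (0.05 log units; within the scatter)) nor methyl (a 1.1-fold lower number from compound 1 to compound 4 (0.05 log units; within the scatter)) can be told apart, so neither group shows any effect of its own here, and the position tolerates both. Methoxy alone stands apart (a 5.6-fold lower number from compound 2 to compound 4 (0.74 log units; beyond the scatter)), which means the earlier gap goes with a higher number for methoxy, not with a lower number for methyl and fluoro, and no evidence at hand speaks to what lies behind this.

Only hydrogen, methyl, fluoro and methoxy are shown at this carbon, so it stays open whether ethoxy or another oxygen-linked group would go with a higher number as methoxy does, or whether chloro, an amine or a carboxylic acid would stay with the other three. On these data alone, all four compounds also share the rest of their structure, so whether the methoxy gap would appear with changes elsewhere on the shared core remains unknown.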